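Swapping the Naphthyl Group on a Shared Core

The compounds below may be only part of what the source reports. "The series", "measured", "known", "first", "only" and "open" are said of these compounds alone.

Compound 1 `CC1OC2(C=CC(=O)C=C2)N(c2nc(-c3ccc4ccccc4c3)nn2-c2ccccc2)C1=O`: 310 nM
Compound 2 `Cc1ccc(-n2nc(-c3ccc4ccccc4c3)nc2N2C(=O)COC23C=CC(=O)C=C3)cc1`: 110 nM
Compound 3 `O=C1C=CC2(C=C1)OCC(=O)N2c1nc(-c2ccc(F)c3ccccc23)nn1-c1ccccc1`: 320 nM

In a functional assay on A549 cells (Homo sapiens) for antiproliferative activity, with a stated time of 5 days (on this read-out higher numbers stand for weaker inhibition and lower numbers for stronger inhibition), compound 3 gives 320 nM, and compound 1 gives 310 nM. These two values lie within the scatter of each other. Compound 2 gives 110 nM, a number lower than that of compound 3 by more than the scatter.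

The next compound to be measured is compound 4 `O=C1C=CC2(C=C1)OCC(=O)N2c1nc(-c2ccc3ccccc3c2)nn1-c1ccccc1`. It carries naphthalen-2-yl in place of 4-fluoronaphthalen-1-yl on an aromatic carbon of the five-membered aromatic ring with 3 nitrogen (naphthalen-2-yl in place of 4-fluoronaphthalen-1-yl on an aromatic carbon). No direct comparison of this change has been measured. Compound 1 at 310 nM and compound 2 at 110 nM both carry naphthalen-2-yl, but each also differs from compound 4 elsewhere, so they only bracket the expectation. In this assay, a small move towards stronger inhibition is expected, a 1.6-fold lower number from compound 3 to compound 4 (0.20 log units; within the scatter), and it may not exceed the scatter. The estimated value for compound 4 is 200 nM, with an expected range of 90 nM to 450 nM.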

Compound 4, half-maximal inhibitory concentration: 140 nM
The estimate for compound 4 lay 1.4-fold (0.15 log units) above the measured number; low and high end bracket the measured number.
By their numbers in this assay, from the lowest: compounds 2 and 4 (each within the scatter of the next); then compounds 1 and 3 (each within the scatter of the next).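

In this assay, naphthalen-2-yl in place of 4-fluoronaphthalen-1-yl on the aromatic carbon of the five-membered ring gives a step beyond the scatter (a 2.3-fold lower number from compound 3 to compound 4 (0.36 log units; beyond the scatter)), the first direct sign that the aryl group at this position affects the read-out. With naphthalen-2-yl held constant, hydrogen in place of methyl on a saturated ring carbon also gives a step beyond the scatter (a 2.2-fold lower number from compound 1 to compound 4 (0.35 log units; beyond the scatter)), whereas hydrogen in place of methyl on an aromatic carbon stays within it (a 1.3-fold higher number from compound 2 to compound 4 (0.10 log units; within the scatter)). Nothing shown accounts for these differences.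

The aryl swap changes both the naphthalene attachment point and the fluorine, so their separate contributions remain unresolved. Plain naphthalen-1-yl at this position would be needed to separate them, and how a single phenyl ring would compare also remains open.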